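From 4-aminophenyl to vinyl on the shared core

The source may report more compounds than this note shows. Statements on the series, on what has been measured and on what is new or still open speak of the compounds shown alone.

Compound 1 `O=C(Nc1cccc(F)c1)c1cc(=O)[nH]c2cc(-c3ccccc3)ccc12`: > 20000 nM (a limit)
Compound 2 `O=C(Nc1cccc(F)c1)c1cc(=O)[nH]c2cc(-c3ccsc3)ccc12`: 4300 nM
Compound 3 `Nc1ccc(-c2ccc3c(C(=O)Nc4cccc(F)c4)cc(=O)[nH]c3c2)cc1`: > 20000 nM (a limit)

All three compounds were tested in a functional assay on KYSE-410 cells (Homo sapiens) for antiproliferative activity, read by MTT assay, with a stated time of 72 h; on this read-out lower numbers stand for stronger inhibition and higher numbers for weaker inhibition. Compound 3 gives only a limit, > 20000 nM, and no number.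

Compound 4 `C=Cc1ccc2c(C(=O)Nc3cccc(F)c3)cc(=O)[nH]c2c1` has not yet been measured. It carries vinyl in place of 4-aminophenyl on an aromatic carbon.

Within the data shown here, two measured steps bear on this change, as both exchange the group at that place and both lie beyond the scatter. They are an at least 4.6-fold lower number from compound 1 to compound 2 (0.66 log units; beyond the scatter) and an at least 4.6-fold higher number from compound 2 to compound 3 (0.66 log units; beyond the scatter). A third, a step that the two limits leave unreadable from compound 1 to compound 3, adds nothing on size.

Among the measured compounds, only compound 2 gives a number, 4300 nM. Vinyl itself has not been tested here, so the expectation is loose. A modest shift towards a lower number is expected, an at least 2.5-fold lower number from compound 3 to compound 4 (0.39 log units; beyond the scatter). For compound 4 the estimated value is 8000 nM, with an expected range of 2500 nM to 20000 nM.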

Compound 4, half-maximal inhibitory concentration: 13600 nM
Compound 4: middle estimate off by 1.7-fold (0.23 log units), on the low side; measured number inside the range.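

With vinyl, which has no ring, the position gives a measured number without any aromatic ring attached, yet thiophen-3-yl keeps the lower number in this assay: a 3.2-fold higher number from compound 2 to compound 4 (0.50 log units; beyond the scatter). The steps from the two compounds at the limit are an at least 1.4-fold lower number from compound 3 to compound 4 (0.16 log units; that floor lies within the scatter) and an at least 1.4-fold lower number from compound 1 to compound 4 (0.16 log units; that floor lies within the scatter), so any gain of vinyl over 4-aminophenyl or phenyl remains unestablished. Those floors rest on a limit and not on a number: the limit of > 20000 nM in this assay, at which 2 of the 4 values shown sit.

The compounds shown leave open whether the double bond of vinyl matters, which ethyl at this place would test, and how an amine or a carboxylic acid there would read. They also leave open whether another small ring, such as furan-3-yl or pyridin-3-yl, would match thiophen-3-yl.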